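Methyl to trifluoromethyl on a second ring position

This account rests on a few compounds, and the source may have more. Where it says the series, first, only, none or still open, it means among the compounds named here.

The measured compounds:
compound 1 `Nc1nc(-c2ccc(Cc3ccc(C(F)(F)F)cc3)cc2)cs1` gives 1390 nM
compound 2 `Cc1cccc(Cc2ccc(-c3csc(N)n3)cc2)c1` gives 4810 nM
compound 3 `Cc1ccc(Cc2ccc(-c3csc(N)n3)cc2)cc1` gives 83 nM

These three compounds were tested in an assay on cells for activation of leukotriene A-4 hydrolase (Homo sapiens), with a stated time of 10 min; a higher number here means that more compound is needed for the effect, a lower number that less compound is needed. Compound 3 gives the lowest number of the three. Compound 2 gives the highest: its nearest neighbour is compound 1, and compound 3 lies furthest from it, both gaps being beyond the scatter. Compound 2 and compound 3 share the same atoms joined differently; the difference between the two cores is not broken down here.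

One change has been measured: trifluoromethyl in place of methyl on an aromatic carbon. The step was a 17-fold higher number from compound 3 to compound 1 (1.22 log units; beyond the scatter), a large rise.

Compound 4 `Nc1nc(-c2ccc(Cc3cccc(C(F)(F)F)c3)cc2)cs1` has not yet been measured in this assay. It arises from compound 2 by the following change: trifluoromethyl in place of methyl on an aromatic carbon. This is the same kind of change as that from compound 3 to compound 1, but the place differs: in the measured pair the group sits para to a large group, whereas in compound 4 it sits meta to a large group. The expectation for compound 4 therefore rests on compound 3 and the step of a 17-fold higher number from compound 3 to compound 1 (1.22 log units; beyond the scatter), with the caution that compound 2 already gives 4810 nM and the place is not the same.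

The step expected from compound 2 to compound 4 is a 4.2-fold higher number from compound 2 to compound 4 (0.62 log units; beyond the scatter), a rise somewhat smaller than the measured one. Compound 4 is estimated at 20000 nM, with a range from 5000 nM to 90000 nM.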

Compound 4, concentration for half-maximal activity: 69000 nM
Beside the measured number, compound 4's estimate is 3.5-fold (0.54 log units) below it; the measured number falls inside the stated range.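

In this assay, trifluoromethyl in place of methyl on an aromatic carbon gave a 14-fold higher number from compound 2 to compound 4 (1.16 log units; beyond the scatter), so the number rose on this core as it had on the core of compound 3. Set beside the earlier step, the change carried over at much the same size, even though the place of the group differs between the two pairs: the same change on two cores in this assay, a 17-fold higher number (1.22 log units; beyond the scatter) from compound 3 to compound 1 and a 14-fold higher number (1.16 log units; beyond the scatter) from compound 2 to compound 4, 1.2-fold (0.07 log units) apart, within the scatter of two such steps. Going by these compounds alone, this rests on only two pairs that share the rest of their structure, so it shows neither why the number rises nor that a step of this size would hold on a core that differs elsewhere.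

The compounds shown leave open whether other groups at these two places, such as a chlorine atom, a methoxy group or an amine, would read closer to methyl or to trifluoromethyl in this assay. They also leave open whether a longer chain or a carboxylic acid on that ring would follow the same course, and whether the step seen here would persist once the rest of the shared core is altered.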